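The compounds below may be only part of what the source reports. "The series", "measured", "known", "first", "only" and "open" are said of these compounds alone.

Values in an ADME assay on L02 cells (Homo sapiens) for cytotoxicity, read by MTT assay, with a stated time of 24 h; a higher number here means a weaker inhibitor, a lower number a stronger inhibitor:
- compound 1 `CC(=O)Nc1ccc(S(=O)(=O)N2C/C(=C\c3ccc(C#N)cc3)C(=O)/C(=C/c3ccccc3F)C2)cc1`: 14400 nM
- compound 2 `COc1cc(/C=C2\CN(S(=O)(=O)c3ccc(NC(C)=O)cc3)C/C(=C\c3ccccc3F)C2=O)cc(OC)c1OC`: 14000 nM
- compound 3 `COc1cc(/C=C2\CN(S(=O)(=O)c3ccc(NC(C)=O)cc3)C/C(=C\c3cccc([N+](=O)[O-])c3)C2=O)cc(OC)c1OC`: 15600 nM

Compound 3, at 15600 nM, lies within the scatter of compound 1 and compound 2. The next analogue is compound 4 `COc1cc(/C=C2\CN(S(=O)(=O)c3ccc(NC(C)=O)cc3)C/C(=C\c3ccc(C#N)cc3)C2=O)cc(OC)c1OC`, which has 4-cyanophenyl in place of 3-nitrophenyl on a double-bonded chain carbon bound to a double-bonded ring carbon. Going by the values given here, two measured steps bear on this change. One exchanged 4-cyanophenyl at this kind of carbon, a 1.0-fold lower number from compound 1 to compound 2 (0.01 log units; within the scatter). The other brought in 3-nitrophenyl, a 1.1-fold higher number from compound 2 to compound 3 (0.05 log units; within the scatter). Both stayed within the scatter, so no step beyond the scatter is expected in this assay. The expected step is a 1.1-fold lower number from compound 3 to compound 4 (0.03 log units; within the scatter). For compound 4 the estimated value is 14500 nM, with an expected range of 9000 nM to 23000 nM.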

Compound 4, half-maximal inhibitory concentration: 13600 nM
Beside the measured number, compound 4's estimate is 1.1-fold (0.03 log units) above it, and the stated range covers the measured number.
By their numbers in this assay, from the lowest: compounds 4, 2, 1 and 3 (each within the scatter of the next).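

In this assay, 4-cyanophenyl and 3,4,5-trimethoxyphenyl now appear together on the shared core, and the exchange of 3-nitrophenyl for 4-cyanophenyl stays within the scatter (a 1.1-fold lower number from compound 3 to compound 4 (0.06 log units; within the scatter)). Replacing 2-fluorophenyl with 4-cyanophenyl also stays within it (a 1.0-fold lower number from compound 2 to compound 4 (0.01 log units; within the scatter)), as does replacing 2-fluorophenyl with 3,4,5-trimethoxyphenyl (a 1.1-fold lower number from compound 1 to compound 4 (0.02 log units; within the scatter)). All the aryl groups shown at this kind of carbon are therefore interchangeable in this read-out. Open, on these data alone, is whether a group of another type there, such as an amine or a carboxylic acid, would move the number beyond the scatter. No evidence bears on why these values stay so close.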